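The source may hold more compounds than are shown below. What is called first, only, known or untested is meant among the compounds shown, and "the series" means these compounds.

Compound 1 (`CC1(C)CC(NC(=S)Nc2cccc(Cl)c2)c2cc(Br)ccc2O1`) and compound 2 (`COc1ccccc1NC(=S)NC1CC(C)(C)Oc2ccc(Br)cc21`) share one core and differ only in the group on an amide-type nitrogen. In a functional assay on U-373MG ATCC cells (Homo sapiens) for inhibition, read by MTT assay, with a stated time of 72 h (a lower number here means a stronger inhibitor, a higher number a weaker inhibitor), compound 1 gives 8000 nM and compound 2 gives 22000 nM, so compound 2 has the higher of the two numbers and is the weaker inhibitor. Compound 3 (`CC1(C)CC(NC(=S)NCc2ccccc2)c2cc(Br)ccc2O1`) changes the same place, with benzyl in place of 2-methoxyphenyl on an amide-type nitrogen. Within the data shown here, the only measured step, a 2.8-fold higher number from compound 1 to compound 2 (0.44 log units; beyond the scatter), involved 2-methoxyphenyl in place of 3-chlorophenyl. Resting on that single modest step, a move of similar size or smaller is expected in this assay, with no firm direction. The estimated change is a 1.6-fold lower number from compound 2 to compound 3 (0.20 log units; within the scatter), so no step beyond the scatter is expected. The estimate for compound 3 is 14000 nM, with an expected range from 5000 nM to 40000 nM.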

Compound 3, half-maximal inhibitory concentration: 29000 nM
Compound 3: the middle estimate sits 2.1-fold (0.32 log units) below what was measured; low and high end bracket the measured number.
By their numbers in this assay, from the lowest: compound 1; then compounds 2 and 3 (each within the scatter of the next).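

Putting benzyl in place of 2-methoxyphenyl on the amide-type nitrogen gives a 1.3-fold higher number from compound 2 to compound 3 (0.12 log units; within the scatter) in this assay, so compound 2 and compound 3 cannot be told apart here, even though the oxygen-bearing group has gone and the entering group has one heavy atom fewer. Benzyl in place of 3-chlorophenyl gives a 3.6-fold higher number from compound 1 to compound 3 (0.56 log units; beyond the scatter), a step of the same direction as the one already seen with 2-methoxyphenyl. Among these three compounds, compound 1 is thus the strongest inhibitor, and this position has now shown two different replacements of 3-chlorophenyl that both give a weaker inhibitor.

Still open, going by these compounds, is how 3-chlorobenzyl, a pyridine ring, an amine-bearing phenyl or a longer chain such as 2-phenylethyl would behave at this nitrogen. No evidence is available to explain these numbers.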